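A few compounds are considered here, and "the series" means these few. Any claim that something is new, unique, unknown or untested is made for them only; others in the source may bear on it.

Measured compounds and their values in a functional assay on CHO cells for agonist activity at Free fatty acid receptor 1 (Homo sapiens), read by FLIPR and calcium flux, tested at 100 nM; on this read-out lower numbers stand for a weaker effect and higher numbers for a stronger effect at the one concentration tested:
compound 1, `O=C(O)CC1COc2cc(OCc3nc(-c4ccccc4)cs3)ccc21`, compound 1 gives 0.16%
compound 2, `Cc1nc(-c2ccccc2)oc1COc1ccc2c(c1)OCC2CC(=O)O`, compound 2 gives 7.15%
compound 3, `Cc1nc(-c2ccccc2)sc1COc1ccc2c(c1)OCC2CC(=O)O`, compound 3 gives 54.8%

Compound 3 stands highest of the three numbers in this assay. Its nearest neighbour is compound 2, whose number is lower by a margin beyond the scatter, and compound 1 lies furthest, also beyond the scatter. The values of compound 1 and compound 2 lie within the scatter of each other, so nothing can be said about their order.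

Compound 4, `Cc1nc(-c2cc3ccccc3o2)sc1COc1ccc2c(c1)OCC2CC(=O)O`, has not yet been measured in this assay. It differs from compound 3 in one place: 1-benzofuran-2-yl in place of phenyl on an aromatic carbon. Phenyl leaves and 1-benzofuran-2-yl enters, on an aromatic carbon of a five-membered aromatic ring with 1 nitrogen and 1 sulfur, two ring bonds from the ring atom that bears a large group.

Going by the values given here, no pair of measured compounds here shows a step of this kind, so the expected size of the step from compound 3 to compound 4 in this assay rests on no measured step. A step not clearly beyond the scatter in either direction is expected, with a wide range, as a number 4.8 percentage points lower from compound 3 to compound 4 (within the scatter) expresses. Compound 4 is expected to give 50% in this assay, estimated within 20% to 85%.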

Compound 4, a percentage reported as activity, at one concentration (the size of the read-out at that concentration, not a potency): 14.8%
The estimate for compound 4 lay 35.2 percentage points above the measured number; the whole stated range lies above it.
By their numbers in this assay, from the lowest: compounds 1, 2 and 4 (each within the scatter of the next, the first and the last beyond it); then compound 3.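

In this assay, going by these compounds alone, the aromatic carbon next to the ring nitrogen and next to the ring sulfur proves sensitive to the group it carries: 1-benzofuran-2-yl in place of phenyl gives a number 40 percentage points lower from compound 3 to compound 4 (beyond the scatter), the first reading of any change at this position. The entering group has 9 heavy atoms against 6 for phenyl, adds a five-membered aromatic ring and brings 1 hydrogen-bond acceptor, so a larger group with an added ring at this place does not simply preserve the effect seen with phenyl, and compound 4 gives 14.8% at the one concentration tested. No available measurement bears on why the read-out falls with this change.

With a single replacement at this position, the compounds shown cannot separate the contribution of the fused ring from that of its ring oxygen; a 1-benzothiophen-2-yl or naphthalen-2-yl group at the same place would address that question. Also open, from the compounds shown here alone, is whether a smaller group such as pyridin-2-yl or a substituted phenyl such as 4-fluorophenyl would keep or exceed the effect of compound 3 , and how this single-concentration step relates to potency.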